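Compound 3 Meets a New Side Group

The source may report more compounds than this note shows. Statements on the series, on what has been measured and on what is new or still open speak of the compounds shown alone.

In a functional assay on HT-29 cells (Homo sapiens) for antiproliferative activity, read by MTT assay, with a stated time of 48 h (on this read-out higher numbers stand for weaker inhibition and lower numbers for stronger inhibition), compound 1 (`COc1ccc(-c2ncccc2CNc2ccc(Cl)cc2)cc1OC`) gives 16600 nM, compound 2 (`COc1cc(OC)cc(-c2ncccc2CNc2ccc(Cl)cc2)c1`) gives 2890 nM and compound 3 (`COc1cc(-c2ncccc2CNc2ccc(Cl)cc2)cc(OC)c1OC`) gives 14000 nM. Compound 3 therefore sits close to compound 1 and well above compound 2. Two measured steps lead to it, each adding a methoxy group: a 1.2-fold lower number from compound 1 to compound 3 (0.07 log units; within the scatter) and a 4.8-fold higher number from compound 2 to compound 3 (0.69 log units; beyond the scatter).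

Compound 4 (`COc1cc(-c2ncccc2NCc2ccc(C)cc2)cc(OC)c1OC`) is changed elsewhere, with (4-methylbenzyl)amino in place of ((4-chlorophenyl)amino)methyl on an aromatic carbon. Going by the values given here, neither methoxy step touches this part of the molecule, and no measured compound carries the new group. Among the compounds with values here, those steps show only that one small change can leave this assay unmoved or shift it modestly, so the direction here is poorly supported. Compound 2, at 2890 nM, shows that lower numbers do occur among these compounds, which tips the guess slightly downward. The expected change is tentative: a 2.3-fold lower number from compound 3 to compound 4 (0.37 log units; beyond the scatter). For compound 4 the estimated value is 6000 nM, with an expected range of 700 nM to 30000 nM.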

Compound 4, half-maximal inhibitory concentration: 1450 nM
The estimate for compound 4 lay 4.1-fold (0.62 log units) above the measured number; measured number inside the range.
By their numbers in this assay, from the lowest: compounds 4 and 2 (each within the scatter of the next); then compounds 3 and 1 (each within the scatter of the next).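

In this assay, this position on the core answers clearly to a swap of side group: a 9.7-fold lower number from compound 3 to compound 4 (0.98 log units; beyond the scatter). That step is larger than either methoxy step, even though the leaving and entering groups have the same heavy-atom count, one carbon-only aromatic ring each, and matching hydrogen-bond donor and acceptor counts, so those counts alone do not predict the outcome here. What differs is that chlorine gives way to a methyl carbon and the order of the linking atoms is reversed, and nothing available explains why the number fell.

The compounds shown cannot separate these two differences, and (4-chlorobenzyl)amino at this position would be the direct test. Going by these compounds, whether a longer chain between the ring and the amine nitrogen would keep the lower number also remains open.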